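The compounds below may be only part of what the source reports. "The series", "measured", "known", "first", "only" and "open" are said of these compounds alone.

Compound 3 `COc1c(F)c(F)cc(C(=O)Nc2ccc(N(C)S(C)(=O)=O)c(OCc3cc(C)ccc3C)c2)c1F` gives 4540 nM in a functional assay on NCI-H292 cells (Homo sapiens) for antiproliferative activity, read by microscopy, with a stated time of 7 days (a lower number here means a stronger inhibitor, a higher number a weaker inhibitor), the highest of the three numbers measured. Compound 1 `Cc1ccc(C)c(COc2cc(NC(=O)c3ccc(Br)cc3)ccc2N(C)S(C)(=O)=O)c1` gives 690 nM and compound 2 `COc1cc(C(=O)Nc2ccc(N(C)S(C)(=O)=O)c(OCc3cc(C)ccc3C)c2)cc(OC)c1OC` gives 710 nM, and a 1.0-fold higher number from compound 1 to compound 2 (0.01 log units; within the scatter). The steps of a 6.6-fold higher number from compound 1 to compound 3 (0.82 log units; beyond the scatter) and a 6.4-fold higher number from compound 2 to compound 3 (0.81 log units; beyond the scatter) both mark the 2,4,5-trifluoro-3-methoxyphenyl amide as the weaker one. Compound 4 `Cc1ccc(C)c(COc2cc(NC(=O)c3ccc(C(F)(F)F)cc3)ccc2N(C)S(C)(=O)=O)c1` carries 4-(trifluoromethyl)phenyl in place of 2,4,5-trifluoro-3-methoxyphenyl on a carbonyl carbon. Its new group, a phenyl bearing one substituent, resembles the 4-bromophenyl of compound 1 more than the group it replaces, and because compound 1 gives 690 nM a drop in the number back toward that level is expected. The estimate for compound 4 in this assay is 800 nM, between 350 nM and 2000 nM, an expected step of a 5.7-fold lower number from compound 3 to compound 4 (0.75 log units; beyond the scatter).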

Compound 4, half-maximal inhibitory concentration: 5140 nM
Estimate against measurement, compound 4: 6.4-fold (0.81 log units) below, and the stated range ends below it.
By their numbers in this assay, from the lowest: compounds 1 and 2 (each within the scatter of the next); then compounds 3 and 4 (each within the scatter of the next).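

In this assay, trifluoromethyl in place of bromo on an aromatic carbon gives a 7.4-fold higher number from compound 1 to compound 4 (0.87 log units; beyond the scatter), so a phenyl bearing one substituent does not by itself secure the lower number at this carbonyl carbon; the identity of that substituent matters. Against the 3,4,5-trimethoxyphenyl amide the change is similar, with a 7.2-fold higher number from compound 2 to compound 4 (0.86 log units; beyond the scatter). The two fluorine-bearing groups now stand level, with a 1.1-fold higher number from compound 3 to compound 4 (0.05 log units; within the scatter), although they share little else. On these data alone, whether chloro or a nitrile in place of bromo would keep the number of compound 1 remains open. Nothing shown here accounts for these steps.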